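The compounds below may be only part of what the source reports. "The series", "measured", "known", "first", "only" and "open" are said of these compounds alone.

Measured in a functional assay on A549 cells (Homo sapiens) for antiproliferative activity, read by trypan blue exclusion, with a stated time of 24 h; on this read-out higher numbers stand for weaker inhibition and lower numbers for stronger inhibition:
- compound 1 `O=C1NC(=O)/C(=C/c2cn(Cc3ccccc3)c3ccccc23)N1`: > 40000 nM
- compound 2 `O=C1NC(=O)/C(=C/c2cn(Cc3ccccc3Br)c3ccccc23)N1`: 39500 nM
- compound 3 `COc1ccc(Cn2cc(/C=C3\NC(=O)NC3=O)c3cc(Br)ccc32)cc1`: 25200 nM

Compound 1 gives only a limit of the assay, > 40000 nM, and not a number. This is the limit of > 40000 nM in this assay, at which 1 of the 3 values shown sits. Any comparison that starts from compound 1 is therefore open on one side.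

The unmeasured compound 4 `Cc1ccc(Cn2cc(/C=C3\NC(=O)NC3=O)c3ccccc32)cc1` keeps the core of compound 1 and makes one change, (methyl in place of hydrogen on an aromatic carbon). In words, methyl takes the place of hydrogen on an aromatic carbon, turning benzyl into 4-methylbenzyl.

Within the data shown here, one measured step bears on this change: an at least 1.0-fold lower number from compound 1 to compound 2 (0.00 log units; that floor lies within the scatter). It also replaces hydrogen on an aromatic carbon, in that case with bromo, and it stays within the scatter. No measured single change leads to compound 3, so compound 3 serves only as a general reference, at 25200 nM.

Among the measured compounds shown here, with so little movement in the one comparable step, no shift beyond the scatter is expected in either direction in this assay. The estimated change is an at least 1.0-fold lower number from compound 1 to compound 4 (0.02 log units; that floor lies within the scatter). The assay may well report only a limit again. The expected value for compound 4 is 38000 nM, with an estimated range of 18000 nM to 60000 nM.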

Compound 4, half-maximal inhibitory concentration: 34800 nM
Compound 4: middle estimate off by 1.1-fold (0.04 log units), on the high side; the range from low to high includes it.
By their numbers in this assay, from the lowest: compounds 3, 4 and 2 (each within the scatter of the next). At a limit, above all of these: compound 1.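

In this assay, the change from benzyl to 4-methylbenzyl gives an at least 1.1-fold lower number from compound 1 to compound 4 (0.06 log units; that floor lies within the scatter), so a small carbon group at the place para to a large group behaves like the bromo step: neither shows a shift beyond the scatter. The two substituted benzyl compounds can also be set against each other directly, and 4-methylphenyl in place of 2-bromophenyl gives a 1.1-fold lower number from compound 2 to compound 4 (0.06 log units; within the scatter), so exchanging one substituted ring for the other makes no readable difference here. The step from the unsubstituted benzyl group can be read only as a floor, and its true size stays unknown, because compound 1 stands at a limit and has no exact number: the limit of > 40000 nM in this assay, at which 1 of the 4 values shown sits.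

The compounds shown carry only methyl or bromo on this benzyl ring, so it remains open whether a different group at the same place, such as an amine, a carboxylic acid or a longer chain like butyl, would move the number beyond the scatter. As far as these compounds go, it is also open whether methyl at another place on this ring would behave as it does in compound 4.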